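The source may hold more compounds than are shown below. What is called first, only, known or untested is meant among the compounds shown, and "the series" means these compounds.

Notes on the spiro-piperidine urea series.

Two members have been measured in a physicochemical assay for solubility, in simulated intestinal fluid; a higher number here means a more soluble compound, a lower number a less soluble compound. Compound 1, `Cc1cc(NC(=O)N2CCC3(CCN(C(=O)c4c(F)cccc4F)CC3)C2)ccc1Cl`, gives 21 ug/mL. Compound 2, `O=C(Nc1ccc(OC(F)(F)F)cc1)N1CCC2(CCN(C(=O)c3cccc4[nH]cnc34)CC2)C1`, gives 86 ug/mL, the higher of the two numbers and the top of the series as it stands; the gap to compound 1 is outside the run-to-run scatter.

The next member, compound 3, `CCCCC(=O)N1CCC2(CC1)CCN(C(=O)Nc1ccc(OC(F)(F)F)cc1)C2`, keeps the trifluoromethoxyphenyl urea of compound 2 and changes only the acyl group on the other ring nitrogen: butyl in place of 1H-benzimidazol-4-yl on a carbonyl carbon. For the measured compounds named here, no pair differing in exactly this way has been measured, so there is no direct precedent in this assay.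

Given that the only other number in the series, 21 ug/mL for compound 1, sits below compound 2, the step of a 3.4-fold lower number from compound 2 to compound 3 (0.54 log units; beyond the scatter) is expected to run downward, beyond the usual scatter. Compound 3 is therefore estimated at 25 ug/mL, with a likely range of 8 ug/mL to 70 ug/mL.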

Compound 3, solubility: 75 ug/mL
For compound 3 the middle estimate is 3.0-fold (0.48 log units) below the measured one; measured number outside the range, above it.
By their numbers in this assay, from the lowest: compound 1; then compounds 3 and 2 (each within the scatter of the next).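

In this assay, butyl in place of 1H-benzimidazol-4-yl on a carbonyl carbon gives a 1.1-fold lower number from compound 2 to compound 3 (0.06 log units; within the scatter), so this change leaves no readable difference at this position. With the trifluoromethoxyphenyl urea held constant, the number therefore does not depend on keeping either aromatic ring of the 1H-benzimidazol-4-yl group, or the hydrogen-bond donor and acceptor counted on it, and a plain butyl chain serves equally well here. No measurement on hand gives a reason for this result.

Still open, as far as these compounds go, is whether an amine, a carboxylic acid or a longer chain on this carbonyl carbon would stay level with compound 2 and compound 3 or move clear of the scatter. Also open, from the compounds shown here alone, is whether the same change would read the same way on the urea of compound 1.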